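The source may hold more compounds than are shown below. What is called first, only, known or untested is meant among the compounds shown, and "the series" means these compounds.

Working notes on the series. In a functional assay on MCF7 cells (Homo sapiens) for inhibition, read by CCK-8 assay, with a stated time of 48 h (on this read-out lower numbers stand for stronger inhibition and higher numbers for weaker inhibition), compound 1 `COc1cc(-c2ccnc3cc(-c4c[nH]c5ccccc45)nn23)cc(OC)c1OC` gives 85 nM, and compound 2 `COc1cc(-c2ccnc3cc(-c4ccc(C)cc4)nn23)cc(OC)c1OC` gives 47 nM. Those two values lie within the scatter of each other: a 1.8-fold lower number from compound 1 to compound 2 (0.26 log units; within the scatter). Compound 3 `COc1cc(-c2ccnc3cc(-c4ccc(C(F)(F)F)cc4)nn23)cc(OC)c1OC` gives 2440 nM, the highest of the three numbers, and it stands well apart: a 29-fold higher number from compound 1 to compound 3 (1.46 log units; beyond the scatter), and a 52-fold higher number from compound 2 to compound 3 (1.72 log units; beyond the scatter). Compound 1 therefore sits with compound 2 at the low end.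

Compound 4 `COc1cc(-c2ccnc3cc(-c4cn(C(=O)OC(C)(C)C)c5ccccc45)nn23)cc(OC)c1OC` differs from compound 1 by tert-butoxycarbonyl in place of hydrogen on an aromatic nitrogen, with tert-butoxycarbonyl in place of hydrogen on an aromatic nitrogen. Going by the values given here, no measured step makes this change, so the evidence is indirect. Among the compounds with values here, replacing 1H-indol-3-yl gave a step within the scatter with compound 2 but a large one with compound 3, and the single swap of methyl for trifluoromethyl was also large. Both outcomes are therefore open, and a moderate rise in the number in this assay is expected, beyond the scatter but short of the largest steps. The expected step is a 4.1-fold higher number from compound 1 to compound 4 (0.61 log units; beyond the scatter). For compound 4 the estimated value is 350 nM, with an expected range of 70 nM to 2500 nM.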

Compound 4, half-maximal inhibitory concentration: 268 nM
Estimate against measurement, compound 4: 1.3-fold (0.12 log units) above, and the stated range covers the measured number.
By their numbers in this assay, from the lowest: compounds 2 and 1 (each within the scatter of the next); then compound 4; then compound 3.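

Going by these compounds alone, until now, the 1H-indol-3-yl group had only been exchanged whole; compound 4 is the first change on its aromatic nitrogen, and in this assay tert-butoxycarbonyl in place of hydrogen gives a 3.2-fold higher number from compound 1 to compound 4 (0.50 log units; beyond the scatter). This modest step shows that the position accepts a group of this size with some loss of inhibition, but it cannot separate the loss of the hydrogen from the arrival of tert-butoxycarbonyl. No measurement at hand explains the rise in the number.

The compounds shown leave open whether a smaller group such as acetyl, or a chain carrying an amine such as 2-aminoethyl, on this aromatic nitrogen would stay within the scatter of compound 1. They also leave open whether a carboxylic acid on such a chain would be accepted there.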